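The source may report more compounds than this note shows. Statements on the series, on what has been measured and on what is new or still open speak of the compounds shown alone.

Compound 1 `CCCOC(=O)C1=C(C)NC(=S)NC1c1ccsc1` and compound 2 `CC1=C(C(=O)OCC(C)C)C(c2ccsc2)NC(=S)N1` share one core and differ only in the ester chain. In an assay on membranes from HEK293 cells for displacement of a labelled ligand from adenosine receptor A2b (Homo sapiens), read by scintillation counting, with a stated time of 30 min, tested at 1 uM (a lower number here means less inhibition, a higher number more inhibition at the concentration tested (going by the name of the read-out)), compound 1 gives 26%, and in the same assay compound 2 gives 15%. For the measured compounds named here, the step of a number 11 percentage points lower from compound 1 to compound 2 (beyond the scatter) lies beyond the scatter, so compound 2 stands lowest of the two numbers measured so far. Compound 3 `CC1=C(C(=O)OCc2ccccc2)C(c2ccsc2)NC(=S)N1` differs from compound 2 in one place: phenyl in place of isopropyl on a saturated chain carbon bound to an oxygen next to a carbonyl group. Going by the values given here, the only measured step, a number 11 percentage points lower from compound 1 to compound 2 (beyond the scatter), also changed the ester chain but by a different swap, so it offers no direct guide to an exchange of isopropyl for phenyl. With so little to build on, the step of a number 3 percentage points higher from compound 2 to compound 3 (within the scatter) is expected to be small, within or only just beyond the scatter, in either direction. For compound 3 the estimated value in this assay is 18%, with a range from 4% to 36%.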

Compound 3, a percentage reported as inhibition, at one concentration (the size of the read-out at that concentration, not a potency): 10%
Compound 3: the middle estimate sits 8 percentage points above what was measured; measured number inside the range.
By their numbers in this assay, from the lowest: compounds 3 and 2 (each within the scatter of the next); then compound 1.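

In this assay, phenyl in place of isopropyl on a saturated chain carbon bound to an oxygen next to a carbonyl group gives a number 5 percentage points lower from compound 2 to compound 3 (within the scatter) and so leaves the number indistinguishable, even though this swap brings in a six-membered aromatic ring. Read from the other neighbour, phenyl in place of ethyl at the same place gives a number 16 percentage points lower from compound 1 to compound 3 (beyond the scatter) and shows that compound 2 and compound 3 both lie beyond the scatter from compound 1, with less inhibition at the concentration tested. No supporting evidence at hand bears on why the numbers fall this way.

On these data alone, it remains open whether a longer chain, or an amine or a carboxylic acid on the ester chain, would shift the number beyond the scatter in either direction. Because each compound is read at a single concentration, these percentages also leave their potencies open.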